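From furan-3-yl to phenyl at the assay limit

The source may hold more compounds than are shown below. What is called first, only, known or untested is meant among the compounds shown, and "the series" means these compounds.

In a functional assay on A549 cells (Homo sapiens), read by MTT assay, with a stated time of 72 h (a lower number here means a stronger inhibitor, a higher number a weaker inhibitor), compound 1 `CNc1ncnc2c1c(-c1ccco1)cn2[C@@H]1O[C@H](CO)[C@@H](O)[C@H]1O` gives 2570 nM as its half-maximal inhibitory concentration, and compound 2 `C#Cc1cn([C@@H]2O[C@H](CO)[C@@H](O)[C@H]2O)c2ncnc(C)c12` gives 19200 nM on the same read-out. Compound 3 `Nc1nc2c(c(-c3ccoc3)cn2[C@@H]2O[C@H](CO)[C@@H](O)[C@H]2O)c(=O)[nH]1` returns only a limit, > 20000 nM in this test, the sole such result among the three. Compound 4 `Nc1nc2c(c(-c3ccccc3)cn2[C@@H]2O[C@H](CO)[C@@H](O)[C@H]2O)c(=O)[nH]1` carries phenyl in place of furan-3-yl on an aromatic carbon and is otherwise unchanged. Within the data shown here, no measured pair differs in one place, so the size of this step is a judgement. In this assay the estimated step of a number no higher from compound 3 to compound 4 (the limit leaves the size open) is expected to stay within the scatter, in neither direction beyond it. Compound 4 is expected at 20000 nM with a range from 8000 nM to 50000 nM as estimated here.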

Compound 4, half-maximal inhibitory concentration: > 100000 nM
Compound 4 ended at the assay's limit; the forecaster's own chance of this, stated with the estimate: 70%; at least 5.0-fold (0.69 log units) between middle value and limit.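

The step from compound 3 to compound 4 cannot be read, as each gives only a limit in this assay. The compounds shown leave open whether phenyl in place of furan-3-yl changes inhibition at all.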